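The source may hold more compounds than are shown below. What is called first, only, known or untested is meant among the compounds shown, and "the series" means these compounds.

Three compounds have so far been measured in a functional assay for antagonist activity at Adrenergic receptor alpha-1 (Rattus norvegicus); on this read-out lower numbers stand for tighter binding and higher numbers for weaker binding:

compound 1, `O=c1cc(-c2ccccc2)oc2cc(OCCCN3CCN(c4ccccc4)CC3)ccc12`, with 6.65 nM;
compound 2, `O=c1cc(-c2ccc(Cl)cc2)oc2cc(OCCCN3CCN(c4ccccc4)CC3)ccc12`, with 8.47 nM;
compound 3, `O=c1cc(-c2ccccc2)oc2cc(OCCCCBr)ccc12`, with 290 nM.

Compound 1 and compound 2 share the same core and differ at a single place: chloro in place of hydrogen on an aromatic carbon. That change brought a 1.3-fold higher number from compound 1 to compound 2 (0.11 log units; within the scatter), a step that falls within the usual scatter of such measurements, so the two values show no clear difference between them. Compound 3 has a different core; how the cores of compound 1 and compound 3 differ is not broken down here. What the numbers show is that compound 3 stands well above both compound 1 and compound 2, and the gaps to each of them are beyond the scatter.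

Compound 4, `O=c1cc(-c2ccc(Cl)cc2)oc2cc(OCCCCBr)ccc12`, has not yet been measured. It differs from compound 3 by chloro in place of hydrogen on an aromatic carbon. This is the same change that separates compound 1 from compound 2, described at a place that reads the same word for word in both cases. Because the earlier change gave a 1.3-fold higher number from compound 1 to compound 2 (0.11 log units; within the scatter), the step in this assay is expected to be similarly small: a 1.2-fold higher number from compound 3 to compound 4 (0.08 log units; within the scatter). This expectation rests on one measured pair only, and on a different core, so the range around it is kept wide.

Compound 4 is therefore estimated at 350 nM in this assay, expected to lie somewhere between 150 nM and 850 nM.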

Compound 4, dissociation constant: 429 nM
The estimate for compound 4 lay 1.2-fold (0.09 log units) below the measured number; the measured number falls inside the stated range.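

In this assay, placing chloro in place of hydrogen on an aromatic carbon gave a 1.5-fold higher number from compound 3 to compound 4 (0.17 log units; within the scatter), so turning phenyl into 4-chlorophenyl brought no clear difference on this core. Set beside the same change on the other core, the two steps agree with each other, which means that a step too small to stand out from the scatter on one core was also too small to stand out on the other: the same change on two cores in this assay, a 1.3-fold higher number (0.11 log units; within the scatter) from compound 1 to compound 2 and a 1.5-fold higher number (0.17 log units; within the scatter) from compound 3 to compound 4, 1.2-fold (0.06 log units) apart, within the scatter of two such steps. Within the data shown here, this shows that, for these two cores and in this one assay, the earlier pair was a fair guide to the later one, but it rests on only two pairs, and two steps within the scatter cannot show whether the change has a small real effect or none at all, nor that the same would hold on every core.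

The compounds shown leave open whether another group at the same place, such as fluoro, methoxy, an amine or a carboxylic acid, would also leave the number within the scatter. They also leave open whether chloro would behave the same way on a third core, for example one carrying a longer chain.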